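Iodine in Place of Methyl at the Same Aromatic Carbon

A few compounds are considered here, and "the series" means these few. Any claim that something is new, unique, unknown or untested is made for them only; others in the source may bear on it.

Compound 1 `Cc1ccc(NC(=O)Nc2nc(-c3cc4ccccc4o3)cs2)cc1` gives the lowest number of the three measured compounds in a physicochemical assay, with a stated time of 6 min (on this read-out lower numbers stand for stronger inhibition and higher numbers for weaker inhibition), at 500 nM. Compound 2 `O=C(Nc1ccc(F)cc1)Nc1nc(-c2cc3ccccc3o2)cs1` gives 1130 nM, and compound 3 `O=C(Nc1cccc(F)c1)Nc1nc(-c2cc3ccccc3o2)cs1` gives 4520 nM. The measured steps are a 2.3-fold higher number from compound 1 to compound 2 (0.35 log units; beyond the scatter), a 9.0-fold higher number from compound 1 to compound 3 (0.96 log units; beyond the scatter) and a 4.0-fold higher number from compound 2 to compound 3 (0.60 log units; beyond the scatter); the latter two also move the substituent to another place. Compound 4 `O=C(Nc1ccc(I)cc1)Nc1nc(-c2cc3ccccc3o2)cs1` differs from compound 1 by iodo in place of methyl on an aromatic carbon. Among the compounds with values here, only the step from compound 1 to compound 2 bears directly on this change, as it swaps the group on the same aromatic carbon, and that step was modest and beyond the scatter. The expected step for compound 4 is a 1.5-fold higher number from compound 1 to compound 4 (0.18 log units; within the scatter). Compound 4 is estimated at 750 nM, within a range of 300 nM to 1900 nM.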

Compound 4, half-maximal inhibitory concentration: 62000 nM
For compound 4 the middle estimate is 83-fold (1.92 log units) below the measured one; measured number outside the range, above it.
By their numbers in this assay, from the lowest: compound 1; then compound 2; then compound 3; then compound 4.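

In this assay this aromatic carbon proved far more sensitive to the group it carries than the earlier modest step suggested, as shown by iodo in place of methyl (a 120-fold higher number from compound 1 to compound 4 (2.09 log units; beyond the scatter)) and iodo in place of fluoro (a 55-fold higher number from compound 2 to compound 4 (1.74 log units; beyond the scatter)). The 4-iodophenyl group also stands well above the 3-fluorophenyl group (a 14-fold higher number from compound 3 to compound 4 (1.14 log units; beyond the scatter)), so the highest number of the set now belongs to this carbon's substitution. Nothing available explains this result. On these data alone, whether chloro or bromo on this carbon would stay near methyl or approach iodo remains open, as does the outcome with an amine or a methoxy group there.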